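Carboxy in Place of Chloro: What to Expect for Compound 4

The compounds below may be only part of what the source reports. "The series", "measured", "known", "first", "only" and "open" are said of these compounds alone.

Measured compounds and their values:
Compound 1, `O=C(/C=C/c1ccc2c(c1)B(O)OC2)c1ccc(Cl)cc1`: 9300 nM
Compound 2, `O=C(/C=C/c1ccc2c(c1)B(O)OC2)c1cccc(F)c1`: 6700 nM
Compound 3, `Nc1cccc(C(=O)/C=C/c2ccc3c(c2)B(O)OC3)c1`: 4500 nM

In a functional assay on HCT-116 cells (Homo sapiens) for cytotoxicity, read by MTT assay, with a stated time of 48 h (on this read-out higher numbers stand for weaker inhibition and lower numbers for stronger inhibition), compound 1 gives the highest number of the three, meaning the weakest inhibition. The nearest step away from it is a 1.4-fold lower number from compound 1 to compound 2 (0.14 log units; within the scatter); the furthest is a 2.1-fold lower number from compound 1 to compound 3 (0.32 log units; beyond the scatter). The remaining step, a 1.5-fold lower number from compound 2 to compound 3 (0.17 log units; within the scatter), separates the two other compounds.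

Compound 4, `O=C(O)c1ccc(C(=O)/C=C/c2ccc3c(c2)B(O)OC3)cc1`, differs from compound 1 as follows: carboxy in place of chloro on an aromatic carbon. Going by the values given here, no measured step introduces a carboxy group, and the two steps that leave compound 1 exchange the chloro for a different group on a different aromatic carbon, each lowering the number only a little. A step of similar modest size, or none beyond the scatter, is therefore expected here. Compound 4 is estimated at 7000 nM, with a range from 2500 nM to 20000 nM, which is expected to amount to a 1.3-fold lower number from compound 1 to compound 4 (0.12 log units; within the scatter).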

Compound 4, half-maximal inhibitory concentration: > 100000 nM
Compound 4 ended at the assay's limit; the forecaster's own chance of this, stated with the estimate: 10%; middle value at least 14-fold (1.15 log units) from the limit.
By their numbers in this assay, from the lowest: compounds 3, 2 and 1 (each within the scatter of the next, the first and the last beyond it). At a limit, above all of these: compound 4.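

In this assay, going by these compounds alone, carboxy in place of chloro on an aromatic carbon gives an at least 10-fold higher number from compound 1 to compound 4 (1.03 log units; beyond the scatter), the only large step in this set. Compound 4 sits at a limit of the assay, not at a number: the limit of > 100000 nM in this assay, at which 1 of the 4 values shown sits. This aromatic carbon, para to a large group, therefore responds strongly to what it carries, which the small steps among compounds 1, 2 and 3 did not reveal.

The compounds shown leave open whether a methyl ester or an amide on this same carbon would stay close to compound 1 or fall away like the carboxy group.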